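The source may report more compounds than this note shows. Statements on the series, on what has been measured and on what is new or still open speak of the compounds shown alone.

Compound 1 `CCC(C)(C)Cc1c[nH]c(CCc2ccc(-n3cncn3)cc2)n1` gives 570 nM in a functional assay on HEK293 cells for agonist activity at Bombesin receptor subtype-3 (Homo sapiens), read by luminescence and calcium flux, with a stated time of 10 min; a lower number here means that less compound is needed, a higher number that more compound is needed for the effect.
Compound 2 `CCC(C)(C)Cc1c[nH]c(CCc2ccc(N3CCCCC3)cc2)n1` gives 171 nM in this assay.

Within the data shown here, of these two numbers, compound 2 holds the lower one; the only measured step is a 3.3-fold lower number from compound 1 to compound 2 (0.52 log units; beyond the scatter). Compound 3 `CCC(C)(C)Cc1c[nH]c(CCc2ccc(-c3cccnc3C(=O)O)cc2)n1` differs from compound 2 by 2-carboxypyridin-3-yl in place of piperidin-1-yl on an aromatic carbon. Among the measured compounds shown here, the one known step bears on it only loosely, since it exchanged a five-membered aromatic heterocycle for piperidin-1-yl, whereas here piperidin-1-yl gives way to a six-membered aromatic heterocycle bearing a carboxylic acid. Compound 3 is therefore expected to need more compound than compound 2, a step of an 8.8-fold higher number from compound 2 to compound 3 (0.94 log units; beyond the scatter), with an estimate of 1500 nM and a range from 400 nM to 6000 nM.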

Compound 3, half-maximal effective concentration: 1260 nM
For compound 3 the middle estimate is 1.2-fold (0.08 log units) above the measured one, and the stated range covers the measured number.
By their numbers in this assay, from the lowest: compound 2; then compound 1; then compound 3.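

At this position, on an aromatic carbon of a six-membered aromatic ring of carbon only, 2-carboxypyridin-3-yl gives up ground to piperidin-1-yl, with a 7.4-fold higher number from compound 2 to compound 3 (0.87 log units; beyond the scatter). It also falls behind 1H-1,2,4-triazol-1-yl, with a 2.2-fold higher number from compound 1 to compound 3 (0.34 log units; beyond the scatter), so piperidin-1-yl now leads two aromatic replacements rather than one. No evidence at hand explains these steps.

Still open, going by these compounds, is whether the step belongs to the ring or to its carboxylic acid, which a plain pyridin-3-yl or a methyl ester would separate. Also open, on these data alone, is whether morpholin-4-yl would match piperidin-1-yl.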